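The compounds below may be only part of what the source reports. "The series", "measured", "known", "first", "only" and "open" are said of these compounds alone.

Compound 2 `O=C(Nc1c(C(O)(C(F)(F)F)C(F)(F)F)ccc2ccccc12)c1ccc(Br)cc1` gives 47 nM in an assay on LtK cells with ATP-sensitive inward rectifier potassium channel 11 (Homo sapiens) as the target (a higher number here means that more compound is needed for the effect, a lower number that less compound is needed), the low end of the two numbers measured, though compound 1 `O=C(Nc1c(C(O)(C(F)(F)F)C(F)(F)F)ccc2ccccc12)c1cccc(Br)c1` with 80 nM sits within the scatter of it, as the step of a 1.7-fold lower number from compound 1 to compound 2 (0.23 log units; within the scatter) shows. Compound 3 `Cc1ccc(C(=O)Nc2c(C(O)(C(F)(F)F)C(F)(F)F)ccc3ccccc23)cc1` differs from compound 2 by methyl in place of bromo on an aromatic carbon. Among the measured compounds shown here, no measured step replaces one group with another at this spot; the only step known shifts the bromo to another carbon and stays within the scatter. Compound 3 is therefore expected to give about 60 nM, between 25 nM and 150 nM. That estimate means a step of a 1.3-fold higher number from compound 2 to compound 3 (0.11 log units; within the scatter), expected to stay within the scatter.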

Compound 3, half-maximal effective concentration: 76 nM
The estimate for compound 3 lay 1.3-fold (0.10 log units) below the measured number; low and high end bracket the measured number.
By their numbers in this assay, from the lowest: compounds 2, 3 and 1 (each within the scatter of the next).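

Among the compounds shown here, this is the first swap of one group for another at this spot. Methyl in place of bromo gives a 1.6-fold higher number from compound 2 to compound 3 (0.21 log units; within the scatter) in this assay and shows that bromine is not required here for a number in this range. Compound 3 also compares with the 3-bromophenyl compound as a 1.1-fold lower number from compound 1 to compound 3 (0.02 log units; within the scatter) and again does not separate from it. No evidence on why is available here. As far as these compounds go, whether this tolerance extends to an amine, a carboxylic acid or a longer chain on this carbon remains open.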